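Swapping the dimethoxyethyl tail for phenyl on compound 1

The compounds below may be only part of what the source reports. "The series", "measured", "known", "first", "only" and "open" are said of these compounds alone.

Measured compounds:
compound 1 `COC(CCn1cnc2c(NCc3ccc(C(=O)Nc4ccccc4N)cc3)nc(Cl)nc21)OC`, 51.2%
compound 2 `CCCCn1cnc2c(Nc3ccccc3)nc(NCOCc3ccc(C(=O)Nc4ccccc4N)cc3)nc21`, 51.3%

Of the compounds shown here, two have been measured in a functional assay on NCI-H460 cells (Homo sapiens) for antiproliferative activity, read by CCK-8 assay, with a stated time of 72 h, tested at 8 uM; a higher number here means a stronger effect of the compound at the concentration tested, a lower number a weaker effect. Compound 1 `COC(CCn1cnc2c(NCc3ccc(C(=O)Nc4ccccc4N)cc3)nc(Cl)nc21)OC` gives 51.2% in this assay. Compound 2 `CCCCn1cnc2c(Nc3ccccc3)nc(NCOCc3ccc(C(=O)Nc4ccccc4N)cc3)nc21` gives 51.3% in this assay. Within the data shown here, these two numbers lie within the usual scatter of each other, so nothing can be said about which of the two acts more strongly; compound 1 simply stands at the same level as the only other measured compound.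

The new compound, compound 3 `Nc1ccccc1NC(=O)c1ccc(CNc2nc(Cl)nc3c2ncn3Cc2ccccc2)cc1`, differs from compound 1 in one place: phenyl in place of 2,2-dimethoxyethyl on a saturated chain carbon bound to an aromatic nitrogen. The shared core and the amide-bearing part are unchanged. Among the measured compounds shown here, no pair of measured compounds shows what such a change does, so there is no measured step to lean on. The expectation for compound 3 is that this change brings no step beyond the scatter, with the step of a number 3.8 percentage points higher from compound 1 to compound 3 (within the scatter) estimated as small. Compound 3 is therefore expected to give about 55% in this assay, with a range from 35% to 75%.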

Compound 3, a percentage reported as inhibition, at one concentration (the size of the read-out at that concentration, not a potency): 46.4%
Estimate against measurement, compound 3: 8.6 percentage points above; the range from low to high includes it.
By their numbers in this assay, from the lowest: compounds 3, 1 and 2 (each within the scatter of the next).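

Among these compounds, this is the first measured step at this place, on a saturated chain carbon bound to an aromatic nitrogen, and in this assay it reads a number 4.8 percentage points lower from compound 1 to compound 3 (within the scatter), with the rest of the molecule unchanged. The hydrogen-bond acceptors of 2,2-dimethoxyethyl can therefore be traded for the six-membered aromatic ring of phenyl, at the same count of heavy atoms, without a step beyond the scatter in this read-out. Nothing in the available data speaks to the reason behind this result.

One step at one tested concentration leaves open whether this place accepts groups of quite different kinds, such as a primary amine, a carboxylic acid or a longer chain, and stays at the same level in this assay. It also leaves open whether the same exchange would read alike in a compound that differs elsewhere, such as compound 2, and whether compounds at the same level here would also match in potency, which a reading at a single concentration cannot show.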